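Swapping a saturated ring for a chlorinated aromatic at the amide side chain

The compounds below may be only part of what the source reports. "The series", "measured", "known", "first", "only" and "open" are said of these compounds alone.

Measured so far:
compound 1, `COC(=O)c1nc(C)c2c(c1N)C(=O)N(Cc1ccccc1)C2=O`: 7400 nM
compound 2, `Cc1noc(-c2nc(C)c3c(c2N)C(=O)N(CC2CCOCC2)C3=O)n1`: 5700 nM

Of the compounds shown here, two sharing the same core have been measured in a physicochemical assay for solubility, using the shake flask method, in simulated intestinal fluid, measured as kinetic solubility, with a stated time of 2 h, at 25 degrees C, at pH 6.5; a higher number here means a more soluble compound, a lower number a less soluble compound. Compound 1, `COC(=O)c1nc(C)c2c(c1N)C(=O)N(Cc1ccccc1)C2=O`, gives 7400 nM in this assay. Compound 2, `Cc1noc(-c2nc(C)c3c(c2N)C(=O)N(CC2CCOCC2)C3=O)n1`, gives 5700 nM in this assay. Within the data shown here, compound 2 stands at the lower of the two numbers, with compound 1 as its only neighbour, and the gap between them lies within the scatter of this kind of measurement, so the two cannot be ranked against each other.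

Compound 3, `Cc1noc(-c2nc(C)c3c(c2N)C(=O)N(Cc2ccccc2Cl)C3=O)n1`, has not yet been measured. It differs from compound 2 in one place: 2-chlorophenyl in place of oxan-4-yl on a saturated chain carbon bound to an amide-type nitrogen in a ring. Among the measured compounds shown here, no measured pair shows this same change, so its effect on this assay is not known from the data at hand.

For compound 3 a decrease in this assay is expected, that is a step of a 2.3-fold lower number from compound 2 to compound 3 (0.36 log units; beyond the scatter). Compound 3 is therefore expected to give about 2500 nM in this assay, with a plausible range from 800 nM to 8000 nM.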

Compound 3, solubility: < 5000 nM
Compound 3 ended at the assay's limit; the forecaster's own chance of this, stated with the estimate: 5%; the middle value is on the limit's open side.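

In this assay compound 3 gives < 5000 nM, which is a limit of the assay and not a number. The change from (oxan-4-yl)methyl to 2-chlorobenzyl provides the only step shown at this position with the rest of the molecule held constant, and it reads as an at least 1.1-fold lower number from compound 2 to compound 3 (0.05 log units; that floor lies within the scatter). That floor does not establish a real loss on its own, and the full size of the step cannot be read because the result for compound 3 stops at a limit: the limit of < 5000 nM in this assay, at which 1 of the 3 values shown sits.

The compounds shown leave open where the true number for compound 3 lies, and how much of any change belongs to the chlorine and how much to the exchange of the saturated ring for an aromatic one, since both differences arrive together in this single step. They also leave open how the number in this assay would respond to an amine or a carboxylic acid placed at the end of the same side chain on the shared core.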